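A few compounds are considered here, and "the series" means these few. Any claim that something is new, unique, unknown or untested is made for them only; others in the source may bear on it.

The series shares the core seen in compound 1 `COc1ccc2c(=O)c(/C=C/C(=O)Nc3cccc(Cl)c3)coc2c1`, an amide bearing a 3-chlorophenyl group, which in a functional assay on HeLa cells (Homo sapiens) for inhibition, read by MTT assay, with a stated time of 48 h (on this read-out higher numbers stand for weaker inhibition and lower numbers for stronger inhibition), gives 11900 nM. Compound 2 `COc1cccc(NC(=O)/C=C/c2coc3cc(OC)ccc3c2=O)c1` carries a 3-methoxyphenyl group instead and gives 19200 nM in this assay, a change of a 1.6-fold higher number from compound 1 to compound 2 (0.21 log units; within the scatter). Compound 3 `COc1ccc2c(=O)c(/C=C/C(=O)NCc3ccccc3F)coc2c1` replaces the aryl amide with a 2-fluorobenzyl amide. In this assay compound 3 reaches only a limit, > 100000 nM, and stands at the limit of > 100000 nM in this assay, at which 1 of the 3 values shown sits. The steps to it were an at least 8.4-fold higher number from compound 1 to compound 3 (0.92 log units; beyond the scatter) and an at least 5.2-fold higher number from compound 2 to compound 3 (0.71 log units; beyond the scatter), both beyond the scatter and both in the direction of weaker inhibition.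

Compound 4 `CCOc1ccc(NC(=O)/C=C/c2coc3cc(OC)ccc3c2=O)cc1` is not yet measured. The change from compound 3 is 4-ethoxyphenyl in place of 2-fluorobenzyl on an amide-type nitrogen. This returns to an aryl amide of the kind found in compound 1 and compound 2, so the two steps that bear on it are those from compound 1 and compound 2 to compound 3, each showing a loss of at least modest size on going to the benzyl amide. The reverse move is therefore expected to give a lower number, near the range of compound 1 and compound 2. For compound 4 the expected step is an at least 5.0-fold lower number from compound 3 to compound 4 (0.69 log units; beyond the scatter). Compound 4 is estimated at 20000 nM, with a range from 6000 nM to 80000 nM.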

Compound 4, half-maximal inhibitory concentration: > 100000 nM
Compound 4 gave a limit, no number; the forecaster's own chance of this, stated with the estimate: 25%; middle value at least 5.0-fold (0.69 log units) away from the limit.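

Returning to an aryl amide did not restore a measurable value in this assay: the 4-ethoxyphenyl group on the amide-type nitrogen gives an at least 5.2-fold higher number from compound 2 to compound 4 (0.71 log units; beyond the scatter) and an at least 8.4-fold higher number from compound 1 to compound 4 (0.92 log units; beyond the scatter). The weak result of compound 3 therefore cannot be tied to the 2-fluorobenzyl group alone, and an aryl group on this nitrogen is not enough to hold a value like those of compound 1 and compound 2, so this position proves sensitive to which aryl group it carries. Compound 4 gives only a limit, so its step from compound 3 cannot be read, and the two compounds now sit together: the limit of > 100000 nM in this assay, at which 2 of the 4 values shown sit.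

The compounds shown leave open whether the loss goes with the ethoxy group itself or with its place on the phenyl ring, and how far beyond the limit compound 3 and compound 4 actually lie. They also leave open how this position would respond to a phenyl ring carrying an amine, a carboxylic acid or a longer chain such as butoxy.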